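Notes on compound 3 and the ring nitrogen methyl

This account rests on a few compounds, and the source may have more. Where it says the series, first, only, none or still open, it means among the compounds named here.

Compound 1 `COc1cccc(Nc2nc(Cl)nc3[nH]cnc23)c1` is the reference point of the series. Within the data shown here, in an assay for inhibition of cytokinin dehydrogenase 2 (Arabidopsis thaliana) (on this read-out higher numbers stand for weaker inhibition and lower numbers for stronger inhibition), compound 1 gives 1900 nM, and it is the only compound with a number on this read-out. Compound 2 `COc1cccc(Nc2nc(SC)nc3[nH]cnc23)c1` reaches the assay limit, > 100000 nM in this assay. The measured step, an at least 52-fold higher number from compound 1 to compound 2 (1.72 log units; beyond the scatter), is a change at an aromatic carbon, and its stated size rests on (the limit of > 100000 nM in this assay, at which 1 of the 2 values shown sits).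

Compound 3 `COc1cccc(Nc2nc(Cl)nc3c2ncn3C)c1` differs from compound 1 in another place: methyl in place of hydrogen on an aromatic nitrogen. Among the measured compounds shown here, none of the measured steps touches this ring nitrogen; the one step in hand, from compound 1 to compound 2, concerns the chloro on an aromatic carbon and gives no guide for a methyl on the ring nitrogen. Without a precedent, the expected step in this assay is a modest weakening, a 2.1-fold higher number from compound 1 to compound 3 (0.32 log units; beyond the scatter), carried with wide uncertainty in either direction. Compound 3 is therefore estimated at 4000 nM, with an expected range from 800 nM to 30000 nM.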

Compound 3, half-maximal inhibitory concentration: 61000 nM
Beside the measured number, compound 3's estimate is 15-fold (1.18 log units) below it, and the stated range ends below it.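

The hydrogen on this ring nitrogen matters far more than a one-carbon change would suggest: in this assay the read-out shows a 32-fold higher number from compound 1 to compound 3 (1.51 log units; beyond the scatter), with the chloro of compound 1 kept in place. Compound 3 carries a measured number rather than an assay limit, so the size of this step can be read directly and does not rest on a cut-off. The series now has two single changes to the core of compound 1, one on an aromatic carbon and one on an aromatic nitrogen, and both move the number upward, while nothing in hand accounts for the size of the step at the ring nitrogen.

From the compounds shown here alone, whether an ethyl group or a longer chain on the same ring nitrogen would raise the number further, or whether a methyl is already enough to lose most of the inhibition, stays open. Also open, going by these compounds, is whether the step seen with the chloro compounds carries over when an amine stands in place of the chloro on the aromatic carbon.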